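The compounds below may be only part of what the source reports. "The series", "measured", "known", "first", "only" and "open" are said of these compounds alone.

Compound 1 `CC1CCC(Nc2nc(C(F)(F)F)ccc2CNC(=O)C(C)c2ccc(NS(C)(=O)=O)c(F)c2)CC1` — 27.2 nM
Compound 2 `CC1CCCN1c1nc(C(F)(F)F)ccc1CNC(=O)[C@@H](C)c1ccc(NS(C)(=O)=O)c(F)c1` — 0.3 nM
Compound 3 `Cc1ccc(CC2CCN(c3nc(C(F)(F)F)ccc3CNC(=O)C(C)c3ccc(NS(C)(=O)=O)c(F)c3)CC2)cc1` — 0.2 nM

In a functional assay on CHO-K1 cells for antagonist activity at transient receptor potential cation channel subfamily V member 1 (Homo sapiens), read by FLIPR (on this read-out lower numbers stand for stronger inhibition and higher numbers for weaker inhibition), compound 1 gives 27.2 nM, the highest of the three numbers. Compound 2 gives 0.3 nM and compound 3 gives 0.2 nM, both far below compound 1 and well beyond the scatter of repeated measurements, so compound 1 is the weakest of the three measured compounds.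

Compound 4 `CC(C(=O)NCc1ccc(C(F)(F)F)nc1N1CCC(=O)CC1)c1ccc(NS(C)(=O)=O)c(F)c1` has not yet been measured. It differs from compound 1 in one place: 4-oxopiperidin-1-yl in place of (4-methylcyclohexyl)amino on an aromatic carbon. Going by the values given here, no step between measured compounds covers exactly this exchange, so the expectation rests on the gap between compound 1 and the two cyclic-amine compounds. A downward step in this assay of moderate to large size is expected, though not as far as compound 2 or compound 3 reach. Compound 4 is therefore estimated at 3 nM, within a range from 0.5 nM to 20 nM. That estimate corresponds to an expected step of a 9.1-fold lower number from compound 1 to compound 4 (0.96 log units; beyond the scatter).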

Compound 4, inhibition constant: 91 nM
For compound 4 the middle estimate is 30-fold (1.48 log units) below the measured one; the whole stated range lies below it.
By their numbers in this assay, from the lowest: compounds 3 and 2 (each within the scatter of the next); then compound 1; then compound 4.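

In this assay, putting 4-oxopiperidin-1-yl in place of (4-methylcyclohexyl)amino on this aromatic carbon gives a 3.3-fold higher number from compound 1 to compound 4 (0.52 log units; beyond the scatter). A ring attached through its nitrogen therefore does not by itself bring a low number here, although compound 3, also attached that way, gives 0.2 nM. No measurement available here explains this rise.

Still open, on these data alone, is whether the carbonyl or the ring as a whole accounts for the higher number. A piperidine ring bearing a hydroxyl group in place of the carbonyl would help separate the two.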